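A few compounds are considered here, and "the series" means these few. Any claim that something is new, unique, unknown or untested is made for them only; others in the source may bear on it.

Measured in a functional assay on the whole organism with Rattus norvegicus as the target; on this read-out lower numbers stand for an effect already at smaller amounts and higher numbers for an effect only at larger amounts of compound:
- compound 1 `CCOCCOC(=O)C(=O)Nc1nc(-c2cc(Cl)no2)cs1`: > 30 mg/kg
- compound 2 `COCCOC(=O)C(=O)Nc1nc(-c2cc(Br)no2)cs1`: > 100 mg/kg
- compound 3 `CCOC(=O)C(=O)Nc1nc(-c2cc(C)no2)cs1`: 0.7 mg/kg

Compound 1 stands at a limit of the assay, > 30 mg/kg, and not at a number. Compound 2 likewise gives only a limit, > 100 mg/kg. Going by the values given here, compound 3 holds the only true number, 0.7 mg/kg.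

Compound 4 `CCOCCOC(=O)C(=O)Nc1nc(-c2cc(COC)no2)cs1` keeps the core of compound 1 and takes methoxymethyl in place of chloro on an aromatic carbon. Among the compounds with values here, no measured step isolates this change, so the expectation is loose. In this assay a clear move toward smaller doses is expected, though not all the way to compound 3 at 0.7 mg/kg. The expected step is an at least 3.0-fold lower number from compound 1 to compound 4 (0.47 log units; beyond the scatter). For compound 4 the estimated value is 10 mg/kg, with an expected range from 1 mg/kg to 100 mg/kg.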

Compound 4, dose for half-maximal effect: 0.7 mg/kg
Beside the measured number, compound 4's estimate is 14-fold (1.15 log units) above it; the measured number lies below the stated range.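

Going by these compounds alone, this is the first pair that differs in one place, and it shows that the aromatic carbon next to the ring nitrogen strongly affects the read-out: in this assay, methoxymethyl in place of chloro gives an at least 42-fold lower number from compound 1 to compound 4 (1.63 log units; beyond the scatter). The true size of this step cannot be read, because compound 1 stands at a limit and not at a number: the limit of > 30 mg/kg in this assay, at which 1 of the 4 values shown sits.

The compounds shown leave open how aminomethyl or ethoxymethyl would read at this position. Compound 3 and compound 4 also differ in their ester chains, so methyl and methoxymethyl cannot be compared directly.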